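A few compounds are considered here, and "the series" means these few. Any claim that something is new, unique, unknown or untested is made for them only; others in the source may bear on it.

Measured compounds:
compound 1 `CC1CCC(=NNc2ccccc2)c2ncc(C(=O)O)c(=O)n21` — 1.2 umol/kg
compound 2 `CC1CC/C(=N\Nc2cccc(Br)c2)c2ncc(C(=O)O)c(=O)n21` — > 320 umol/kg
compound 3 `C[C@H]1CC/C(=N\Nc2ccc(O)cc2)c2ncc(C(=O)O)c(=O)n21` — > 100 umol/kg

The study concerns three compounds sharing one core and tested in a functional assay on the whole organism for inhibition, with Rattus norvegicus as the target; a higher number here means that more compound is needed for the effect, a lower number that less compound is needed. Compound 1 gives 1.2 umol/kg. Compound 2 reaches only a limit of the assay, > 320 umol/kg, so no number is known for it; this is the limit described at the limit of > 320 umol/kg in this assay, at which 1 of the 3 values shown sits. Compound 3 likewise reaches only a limit, > 100 umol/kg, the limit described at the limit of > 100 umol/kg in this assay, at which 1 of the 3 values shown sits. Thus the one compound with a number is compound 1, and the two others stand at limits.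

The unmeasured compound 4 `Cc1ccc(N/N=C2\CCC(C)n3c2ncc(C(=O)O)c3=O)cc1` differs from compound 2 in one place: 4-methylphenyl in place of 3-bromophenyl on an amine nitrogen. Among the measured compounds shown here, no measured pair differs in one place, so no step is recorded. Since compound 2 sits at a limit, the step from it in this assay is expected to run toward less compound needed, of the size an at least 10-fold lower number from compound 2 to compound 4 (1.02 log units; beyond the scatter), with wide uncertainty. Compound 4 is expected to give about 30 umol/kg, within 3 umol/kg to 300 umol/kg.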

Compound 4, dose for 50% inhibition: > 1000 umol/kg
Compound 4: only a limit was reported (the forecaster's own chance of this, stated with the estimate: 40%); at least 33-fold (1.52 log units) between middle value and limit.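

Compound 2 and compound 4 both stand only at limits in this assay, so no step can be read between them. The compounds shown leave open what number either compound would give, and so how 4-methylphenyl compares with 3-bromophenyl on the amine nitrogen.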